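A few compounds are considered here, and "the series" means these few. Any claim that something is new, unique, unknown or untested is made for them only; others in the source may bear on it.

Three compounds share a common core and differ only in the group at the far end of the tail. Compound 1 `C#Cc1cccc(Nc2ncnc3cc(OC)c(OCCCCCCN/C(=N\C#N)Nc4cccnc4)cc23)c1`, compound 2 `C#Cc1cccc(Nc2ncnc3cc(OC)c(OCCCCCN/C(=N\C#N)Nc4ccncc4)cc23)c1` and compound 3 `C#Cc1cccc(Nc2ncnc3cc(OC)c(OCCCCCCN/C(=N\C#N)Nc4ccncc4)cc23)c1` were all tested in a functional assay on K562 cells (Homo sapiens) for inhibition, read by CCK-8 assay, with a stated time of 72 h; on this read-out higher numbers stand for weaker inhibition of growth and lower numbers for stronger inhibition of growth. In this assay compound 1 gives 0.16 nM, compound 2 gives 0.1 nM and compound 3 gives 0.15 nM. All three numbers lie within the scatter of one another, so none of the compounds can be called stronger or weaker than the others.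

One structural change is seen twice. From compound 3 to compound 1 it reads pyridin-3-yl in place of pyridin-4-yl on an amine nitrogen and made a step of a 1.1-fold higher number from compound 3 to compound 1 (0.03 log units; within the scatter). How the cores of compound 2 and compound 3 differ is not broken down here. Compound 4 `C#Cc1cccc(Nc2ncnc3cc(OC)c(OCCCCCN/C(=N\C#N)Nc4cccnc4)cc23)c1` has not yet been measured; from compound 2 it differs by pyridin-3-yl in place of pyridin-4-yl on an amine nitrogen, at a place described in exactly the same way, so it is the same change. The step from compound 2 to compound 4 in this assay is expected to be small, a 1.1-fold higher number from compound 2 to compound 4 (0.04 log units; within the scatter), because the earlier step was a 1.1-fold higher number from compound 3 to compound 1 (0.03 log units; within the scatter). Compound 4 is therefore estimated at 0.11 nM, with a likely range from 0.06 nM to 0.22 nM.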

Compound 4, concentration for 50% growth inhibition: 0.98 nM
The estimate for compound 4 lay 8.9-fold (0.95 log units) below the measured number, outside the stated range (above it).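

Putting pyridin-3-yl in place of pyridin-4-yl on the amine nitrogen gives, in this assay, a 9.8-fold higher number from compound 2 to compound 4 (0.99 log units; beyond the scatter), so on this core the change clearly weakens inhibition of growth. On the other core the same change made no step beyond the scatter, and the two results do not agree: the same change on two cores in this assay, a 1.1-fold higher number (0.03 log units; within the scatter) from compound 3 to compound 1 and a 9.8-fold higher number (0.99 log units; beyond the scatter) from compound 2 to compound 4, 9.2-fold (0.96 log units) apart, beyond the scatter of two such steps. This shows that, in these two pairs, the result of the change depends on the core it is made on, so a step seen on one core cannot safely be carried to the other, but two pairs cannot show which feature of the cores is responsible, why it matters, or what would happen on a further core.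

The compounds shown leave open how this change would behave with a longer chain or a shorter chain in the tail. They also leave open whether a plain phenyl on the same amine nitrogen would follow pyridin-4-yl or pyridin-3-yl on each core.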